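The source may hold more compounds than are shown below. What is called first, only, known or untested is meant among the compounds shown, and "the series" means these compounds.

Working notes on the series.

The shared core of compound 3 `COc1cc(-c2nn(-c3cccc(NC(=O)Nc4cccc(C(F)(F)F)c4)c3)cc2-c2ccncc2)ccc1Cl` carries a urea to a trifluoromethyl-substituted phenyl; in a functional assay on BT-549 cells (Homo sapiens) for inhibition, read by sulforhodamine B assay, with a stated time of 48 h (a higher number here means a weaker inhibitor of growth, a lower number a stronger inhibitor of growth), compound 3 gives 1250 nM, the lowest of the three numbers at hand. Compound 1 `O=C(Nc1cccc(-n2cc(-c3ccncc3)c(-c3ccc(Cl)c(O)c3)n2)c1)Nc1cccc(C(F)(F)F)c1` gives 6510 nM; compound 2 `COc1cc(-c2nn(-c3cccc(NC(=O)c4cccc(C(F)(F)F)c4)c3)cc2-c2ccncc2)ccc1Cl` gives 2870 nM. The two steps into compound 3 are a 5.2-fold lower number from compound 1 to compound 3 (0.72 log units; beyond the scatter) and a 2.3-fold lower number from compound 2 to compound 3 (0.36 log units; beyond the scatter).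

Compound 4 `COc1cc(-c2nn(-c3cccc(NC(=O)c4ccccc4)c3)cc2-c2ccncc2)ccc1Cl` is not yet measured. The change from compound 3 is phenyl in place of (3-(trifluoromethyl)phenyl)amino on a carbonyl carbon. For the measured compounds named here, the only measured step that bears on it is a 2.3-fold lower number from compound 2 to compound 3 (0.36 log units; beyond the scatter), which reverses the urea-to-amide part of the change; the loss of the trifluoromethyl group has no counterpart among the measured compounds, so its contribution is unknown. On that basis the expected step is a 3.2-fold higher number from compound 3 to compound 4 (0.51 log units; beyond the scatter), a higher number beyond the scatter. Compound 4 is therefore estimated at 4000 nM, with a range from 1500 nM to 12000 nM.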

Compound 4, concentration for 50% growth inhibition: 1330 nM
The estimate for compound 4 lay 3.0-fold (0.48 log units) above the measured number; measured number below the stated range.
By their numbers in this assay, from the lowest: compounds 3 and 4 (each within the scatter of the next); then compound 2; then compound 1.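

On a carbonyl carbon whose other neighbour is an amide-type nitrogen, phenyl in place of (3-(trifluoromethyl)phenyl)amino gives (a 1.1-fold higher number from compound 3 to compound 4 (0.03 log units; within the scatter)) in this assay, so this larger change leaves the number within the scatter, although the urea-to-amide step alone had been beyond it. Hydrogen in place of trifluoromethyl on an aromatic carbon gives (a 2.2-fold lower number from compound 2 to compound 4 (0.33 log units; beyond the scatter)), the first reading of this group in the series, and within the amide pair the trifluoromethyl compound carries the higher number. No evidence at hand bears on the reason for either step.

Whether the same replacement of trifluoromethyl by hydrogen behaves alike on the urea stays open, as the shown compounds hold no such pair. Equally open, from the compounds shown here alone, is how a methoxy group, an amine or a carboxylic acid on that aromatic carbon would compare.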